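The source may report more compounds than this note shows. Statements on the series, on what has been measured and on what is new or still open speak of the compounds shown alone.

In a functional assay on MDA-MB-231 cells (Homo sapiens) for inhibition, read by sulforhodamine B assay, with a stated time of 48 h (a lower number here means that less compound is tolerated, a higher number that more compound is tolerated), compound 2 `Cc1cc(O)cc(-c2nn(CC#N)cc2-c2ccnc(-c3ccc(Oc4ccccc4)cc3)c2)c1` gives 57700 nM. Compound 1 `COc1cc(C)cc(-c2c(-c3ccnc(-c4ccc(C(C)=O)cc4)c3)cnn2CC#N)c1` reaches only > 100000 nM, which is a limit of the assay and not a number. Among the measured compounds shown here, compound 2 thus stands as the only plain number among the two values shown. Compound 3 `Cc1cc(O)cc(-c2nn(CC#N)cc2-c2ccnc(-c3ccc(N(C)C)cc3)c2)c1` differs by dimethylamino in place of phenoxy on an aromatic carbon. For the measured compounds named here, no step between measured compounds is available, so a change no larger than the usual scatter is expected, a 1.0-fold higher number from compound 2 to compound 3 (0.02 log units; within the scatter). Compound 3 is therefore estimated at 60000 nM, within a range from 20000 nM to 150000 nM.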

Compound 3, concentration lethal to 50% of the cells: > 100000 nM
Compound 3: only a limit was reported; the forecaster's own chance of this, stated with the estimate: 35%; at least 1.6-fold (0.22 log units) between middle value and limit.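

Among the compounds shown here, replacing phenoxy with dimethylamino on an aromatic carbon, para to a large group, gives the only readable step at this position in this assay, an at least 1.7-fold higher number from compound 2 to compound 3 (0.23 log units; that floor lies within the scatter). On these data alone, compound 3 sits at a limit of the assay and not at a number, so this step is only a floor and the true size of the change stays unknown. Little room remains for reading changes in this series, because the values crowd at the top of the assay: the limit of > 100000 nM in this assay, at which 2 of the 3 values shown sit.

As far as these compounds go, whether a primary amine or a carboxylic acid on this carbon would give a plain number remains open.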